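A few compounds are considered here, and "the series" means these few. Any claim that something is new, unique, unknown or untested is made for them only; others in the source may bear on it.

Measured so far: compound 2 `CC(C)(C)c1ccc(C(=O)N2CCC3(CC2)C(=O)N(CC(=O)NCCN)CN3c2ccccc2)cc1` gives 7000 nM in an assay on HEK293 cells for displacement of a labelled ligand from NPC1-like intracellular cholesterol transporter 1 (Homo sapiens); a lower number here means a stronger inhibitor, a higher number a weaker inhibitor; compound 3 `CC(C)(C)c1ccc(C(=O)N2CCC3(CC2)C(=O)N(CC(=O)N2CCCC(O)C2)CN3c2ccccc2)cc1` gives 12200 nM; compound 1 `CC(C)(C)OC(=O)NCCCCNC(=O)CN1CN(c2ccccc2)C2(CCN(C(=O)c3ccc(C(C)(C)C)cc3)CC2)C1=O` has "not determined" (no result reported) as its entry, so no number is reported for it.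

For the measured compounds named here, compound 3 thus carries the higher of the two numbers, but its only neighbour sits within the scatter: a 1.7-fold higher number from compound 2 to compound 3 (0.24 log units; within the scatter). Compound 4 `CC(C)(C)c1ccc(C(=O)N2CCC3(CC2)C(=O)N(CC(=O)NCCCCNS(C)(=O)=O)CN3c2ccccc2)cc1` differs from compound 3 at one place: (4-(methanesulfonamido)butyl)amino in place of 3-hydroxypiperidin-1-yl on a carbonyl carbon. Going by the values given here, the single measured step bears directly on this, since it too exchanged the group on the same carbonyl carbon, and it stayed within the scatter. The new open chain resembles the chain of compound 2 more than the ring of compound 3, so a small move toward the lower number is expected, yet nothing beyond the scatter. Compound 4 is therefore expected at 9000 nM, range 3000 nM to 30000 nM, an estimated step of a 1.4-fold lower number from compound 3 to compound 4 (0.13 log units; within the scatter).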

Compound 4, half-maximal inhibitory concentration: 4500 nM
Compound 4: middle estimate off by 2.0-fold (0.30 log units), on the high side; the measured number falls inside the stated range.
By their numbers in this assay, from the lowest: compounds 4, 2 and 3 (each within the scatter of the next, the first and the last beyond it).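

In this assay the group on this carbonyl carbon now gives its first change beyond the scatter (a 2.7-fold lower number from compound 3 to compound 4 (0.43 log units; beyond the scatter)), as the open (4-(methanesulfonamido)butyl)amino chain replaces the 3-hydroxypiperidin-1-yl ring. The other step (a 1.6-fold lower number from compound 2 to compound 4 (0.19 log units; within the scatter)) stays within the scatter, so the chain of compound 4 cannot be told apart from the shorter, amine-ended chain of compound 2. No measurement shown explains the difference from compound 3. Still open, as far as these compounds go, is how a butyl chain ending in a free amine or a carboxylic acid would compare.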